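Ureidophenyl in Place of Chlorophenyl on a Sulfonyl Sulfur

The source may hold more compounds than are shown below. What is called first, only, known or untested is meant among the compounds shown, and "the series" means these compounds.

Compound 1 `O=C(Nc1ccc(-c2noc(-c3cccc(NS(=O)(=O)c4cccc(Cl)c4)c3)n2)c(Cl)c1)c1cccnc1` was tested in a functional assay on MDA-MB-231 cells (Homo sapiens) for antiproliferative activity, read by MTT assay, with a stated time of 72 h; on this read-out lower numbers stand for stronger inhibition and higher numbers for weaker inhibition. In this assay compound 1 gives > 10000 nM, which is a limit of the assay rather than a number. Compound 2 `COc1cc(NC(=O)c2cccnc2)ccc1-c1noc(-c2cccc(NS(=O)(=O)c3ccc(NC(C)=O)cc3)c2)n1` likewise gives > 10000 nM in this assay, again only a limit. Both values sit at the limit of > 10000 nM in this assay, at which 2 of the 2 values shown sit. Compound 3 `NC(=O)Nc1ccc(S(=O)(=O)Nc2cccc(-c3nc(-c4ccc(NC(=O)c5cccnc5)cc4Cl)no3)c2)cc1` differs from compound 1 by 4-ureidophenyl in place of 3-chlorophenyl on a sulfonyl sulfur. Among the compounds with values here, no measured step accompanies this change, and with compound 1 standing at a limit no direction beyond the scatter can be read. The step of a number no higher from compound 1 to compound 3 (the limit leaves the size open) is therefore only an estimate of no real change. Compound 3 is expected to give 10000 nM in this assay, with a range from 3000 nM to 30000 nM, most likely reported again as a limit.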

Compound 3, half-maximal inhibitory concentration: 2800 nM
Compound 3: the middle estimate sits 3.6-fold (0.55 log units) above what was measured, outside the stated range (below it).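

On the sulfonyl sulfur, 4-ureidophenyl in place of 3-chlorophenyl brings an at least 3.5-fold lower number from compound 1 to compound 3 (0.55 log units; beyond the scatter) in this assay, which shows that the group at this position can move the read-out. From the compounds shown here alone, the starting value of this step is only a limit of the assay, so its full size stays open. Compound 3 alone gives a number here, while the other compounds remain at a limit: the limit of > 10000 nM in this assay, at which 2 of the 3 values shown sit.

Going by these compounds, it remains open whether the whole ureido group is needed. An amine or a carboxylic acid in its place on the phenyl ring might give a different value.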